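This account rests on a few compounds, and the source may have more. Where it says the series, first, only, none or still open, it means among the compounds named here.

Measured compounds:
Compound 1, `Cc1ccc(CC(C)C(=O)N2CCN(c3ccc(C(F)(F)F)cc3[C@@H](N)CC(C)C)CC2)cc1C`, gives 240 nM in an assay on HEK293 cells for displacement of a labelled ligand from Melanocortin receptor 4 (Homo sapiens); a lower number here means a stronger inhibitor, a higher number a weaker inhibitor.
Compound 2, `CC(C)C[C@H](N)c1cc(C(F)(F)F)ccc1N1CCN(C(=O)CSc2ccc(Cl)cc2Cl)CC1`, gives 1500 nM in this assay.
Compound 3, `Cc1ccc(N2CCN(C(=O)[C@H](C)Cc3ccc(Cl)cc3F)CC2)c([C@@H](N)CC(C)C)c1`, gives 20 nM in this assay.

Compound 2 has the highest number of the three in this assay, so it is the weakest binder shown; compound 1 sits nearest to it and compound 3 furthest, both differences beyond the scatter. The new compound 4, `CC(C)C[C@H](N)c1cc(C(F)(F)F)ccc1N1CCN(C(=O)COc2cccc3ccccc23)CC1`, changes the side chain of the amide: (naphthalen-1-yl)oxy in place of (2,4-dichlorophenyl)sulfanyl on a saturated chain carbon bound to a carbonyl carbon.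

Among the compounds with values here, only one measured step touches this part of the molecule, a 6.3-fold higher number from compound 1 to compound 2 (0.80 log units; beyond the scatter), which shows that reshaping the group on the carbonyl carbon can move the number by a modest but real amount. Within the data shown here, no measured pair shows an oxygen-linked or naphthalene-bearing side chain, so the direction of the change from compound 2 to compound 4 is uncertain. Given that compound 2 already has the weakest value and that related side chains in compound 1 and compound 3 give lower numbers, a small improvement is expected, a 1.7-fold lower number from compound 2 to compound 4 (0.22 log units; within the scatter), though a result within the scatter would not be surprising. Compound 4 is therefore estimated at 900 nM in this assay, with a range from 250 nM to 3500 nM.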

Compound 4, inhibition constant: 2600 nM
Estimate against measurement, compound 4: 2.9-fold (0.46 log units) below; low and high end bracket the measured number.
By their numbers in this assay, from the lowest: compound 3; then compound 1; then compounds 2 and 4 (each within the scatter of the next).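

Replacing (2,4-dichlorophenyl)sulfanyl with (naphthalen-1-yl)oxy on a saturated chain carbon bound to a carbonyl carbon gives a 1.7-fold higher number from compound 2 to compound 4 (0.24 log units; within the scatter) in this assay and so leaves the number essentially unmoved, even though the aromatic group and the linking atom both change. Replacing 1-(3,4-dimethylbenzyl)ethyl with ((naphthalen-1-yl)oxy)methyl on a carbonyl carbon gives an 11-fold higher number from compound 1 to compound 4 (1.03 log units; beyond the scatter) and, read with a 6.3-fold higher number from compound 1 to compound 2 (0.80 log units; beyond the scatter) as well, shows that both the sulfur-linked and the oxygen-linked side chains give higher numbers than the 1-(3,4-dimethylbenzyl)ethyl group of this set. Nothing available here explains these results.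

From the compounds shown here alone, whether the linking atom or the aromatic group has any effect on its own remains open, since the two change together in this step. Also open, going by these compounds, is how a side chain ending in an amine or a carboxylic acid would read in this assay at this position.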